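The source may report more compounds than this note shows. Statements on the series, on what has been measured and on what is new or still open speak of the compounds shown alone.

Compound 1 `Cc1ccc(C(=O)/C=C/c2ccc3c(c2)B(O)OC3)cc1` in an ADME assay on L929 cells (Mus musculus) for cytotoxicity, read by resazurin assay, with a stated time of 72 h (on this read-out higher numbers stand for weaker inhibition and lower numbers for stronger inhibition), gives a limit, > 10 ug/mL.
Compound 2 `O=C(/C=C/c1ccc2c(c1)B(O)OC2)c1ccco1` in this assay gives a limit, > 10 ug/mL.
Compound 3 `COCOc1ccccc1C(=O)/C=C/c1ccc2c(c1)B(O)OC2` in this assay gives 9.02 ug/mL.

Compound 2 therefore stands at a limit rather than at a number, namely at the limit of > 10 ug/mL in this assay, at which 2 of the 3 values shown sit. The step that the two limits leave unreadable from compound 1 to compound 2 cannot be read from those two limits. Compound 4 `O=C(/C=C/c1ccc2c(c1)B(O)OC2)c1ccccn1` differs from compound 2 by pyridin-2-yl in place of furan-2-yl on a carbonyl carbon. Among the measured compounds shown here, no measured step bears on this change, and the only step between measured compounds is unreadable, so compound 2 offers only a limit as the starting point. Compound 4 is expected to sit near that limit as well, with the step that the limit leaves unreadable from compound 2 to compound 4 expected to stay within the scatter. Compound 4 is accordingly estimated at 12 ug/mL, within a range from 6 ug/mL to 30 ug/mL.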

Compound 4, half-maximal inhibitory concentration: > 10 ug/mL
Compound 4 ended at the assay's limit; the forecaster's own chance of this, stated with the estimate: 65%; the middle value lies beyond the limit too.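

Compound 1, compound 2 and compound 4 all stand at a limit in this assay, so no step among them can be read: the limit of > 10 ug/mL in this assay, at which 3 of the 4 values shown sit.

How far each of these compounds lies past that limit, and whether their groups on the carbonyl carbon differ at all, stays open.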